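A Benzyl Thioether Replaces the Propargyl Chain

This account rests on a few compounds, and the source may have more. Where it says the series, first, only, none or still open, it means among the compounds named here.

Three measured compounds share one core. Compound 1 `CCCSc1nc(N/N=C/c2ccc(Cl)cc2)c2nnn(Cc3ccccc3)c2n1` in a functional assay on MCF7 cells (Homo sapiens) for antiproliferative activity, read by MTT assay, with a stated time of 72 h (a lower number here means a stronger inhibitor, a higher number a weaker inhibitor), gives only a limit, > 64000 nM. Compound 3 `CCCSc1nc(N/N=C/c2cccs2)c2nnn(Cc3ccccc3)c2n1` likewise gives only a limit in this assay, > 64000 nM. The step that the two limits leave unreadable from compound 1 to compound 3 therefore cannot be read; it is a change that the limit of > 64000 nM in this assay, at which 2 of the 3 values shown sit, hides. Among the compounds with values here, compound 2 `C#CCSc1nc(N/N=C/c2cc(OC)c(OC)c(OC)c2)c2nnn(Cc3ccccc3)c2n1` is the one compound with a number in this assay, giving 17000 nM, and it stands as the only readable point among the three.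

Compound 4 `COc1cc(/C=N/Nc2nc(SCc3ccccc3)nc3c2nnn3Cc2ccccc2)cc(OC)c1OC` differs from compound 2 in one place: phenyl in place of ethynyl on a saturated chain carbon bound to a sulfur. Within the data shown here, no measured step touches the sulfanyl substituent; the only step that two measured compounds define alters the aryl group on the carbon with a double bond to nitrogen, and that step is unreadable. Among the measured compounds shown here, nothing among the measured compounds therefore points in either direction, and the expected step of no change at the digits printed from compound 2 to compound 4 (within the scatter) in this assay is none beyond the scatter. Compound 4 is accordingly estimated at 17000 nM in this assay, with a range from 6000 nM to 50000 nM.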

Compound 4, half-maximal inhibitory concentration: 13500 nM
Beside the measured number, compound 4's estimate is 1.3-fold (0.10 log units) above it; the measured number falls inside the stated range.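

With the propargyl chain changed to a benzyl chain, the sulfanyl substituent gets its only readable step among the compounds shown, a 1.3-fold lower number from compound 2 to compound 4 (0.10 log units; within the scatter) in this assay. At this place, on a saturated chain carbon bound to a sulfur, a group of 2 heavy atoms with a triple bond gives way to a group of 6 with an aromatic ring, and the number stays within the scatter. Nothing given here bears on a cause for this step.

The compounds shown leave open whether an amine or a carboxylic acid at this place would give a step beyond the scatter. They also leave open how the aryl group on the carbon with a double bond to nitrogen acts here, since the steps around it cannot be read: the limit of > 64000 nM in this assay, at which 2 of the 4 values shown sit.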